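A few compounds are considered here, and "the series" means these few. Any claim that something is new, unique, unknown or untested is made for them only; others in the source may bear on it.

Among the compounds with values here, in a functional assay on ACHN cells (Homo sapiens) for inhibition, read by sulforhodamine B assay, with a stated time of 48 h (a lower number here means a stronger inhibitor of growth, a higher number a weaker inhibitor of growth), compound 1 `Cc1cn([C@H]2C[C@H](CC3=CC(=O)C(=O)C=C3)[C@@H](CO[Si](C)(C)C(C)(C)C)O2)c(=O)[nH]c1=O` has no result reported, so compound 2 `COc1ccc(C2([C@H]3C[C@H](n4cc(C)c(=O)[nH]c4=O)O[C@@H]3CO[Si](C)(C)C(C)(C)C)SCCCS2)cc1OC` supplies the only number available, and compound 2 gives 2510 nM. From the compounds shown here alone, a single value allows no ranking and no trend, so its standing remains open.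

Compound 3 `COc1ccc(C2([C@H]3C[C@@H](n4cc(C)c(=O)[nH]c4=O)O[C@@H]3CO[Si](C)(C)C(C)(C)C)SCCCS2)cc1OC` is the next entry to be read against compound 2. The structural change is the two compounds have the same atoms and bonds and differ only in configuration as drawn: 1 of 3 stereo elements differ; a stereocentre at a saturated ring carbon is drawn R in compound 2 and S in compound 3: the two compounds have the same atoms and bonds and differ only in configuration as drawn, with a stereocentre at a saturated ring carbon drawn R in compound 2 and S in compound 3.

Within the data shown here, no measured pair shows what such a change does in this assay, so the data favour no direction. The expectation is therefore no step beyond the scatter, anchored on compound 2 at 2510 nM, with a wide range to cover the lack of any precedent. The expected step of a 1.1-fold higher number from compound 2 to compound 3 (0.03 log units; within the scatter) is small and carries little weight as to direction. Compound 3 is estimated at 2700 nM, with an expected range of 1000 nM to 8000 nM.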

Compound 3, concentration for 50% growth inhibition: 6760 nM
For compound 3 the middle estimate is 2.5-fold (0.40 log units) below the measured one; the measured number falls inside the stated range.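

In this assay, within the data shown here, the change of configuration at the saturated ring carbon gives a 2.7-fold higher number from compound 2 to compound 3 (0.43 log units; beyond the scatter), a modest step and the first reading of any structural change. The configuration at this carbon therefore matters in this assay, and of this pair the R form drawn in compound 2 is the stronger inhibitor of growth, whereas compound 2 alone could give no such comparison. The step can be assigned to this single stereocentre, because nothing else separates the pair: the fact that compounds 2 and 3 differ only in the configuration as drawn.

From the compounds shown here alone, this is one step at one stereocentre, so it remains open whether the other two stereo elements matter to a similar degree, or whether the preference for R at this carbon would persist on a different scaffold of substituents. Compounds carrying an amine or a carboxylic acid on the shared core would show whether the gap between the two configurations holds with other groups, and compound 1 offers no number against which either configuration can be read.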